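Second Chlorine on the Core: Expected Cytotoxicity

A few compounds are considered here, and "the series" means these few. Any claim that something is new, unique, unknown or untested is made for them only; others in the source may bear on it.

Compound 1 `ClCc1cccc(Cn2cnc3c(Cl)ncnc32)c1`: 27500 nM
Compound 2 `ClCc1ccc(Cn2cnc3nc(Cl)nc(Cl)c32)cc1`: 6450 nM

Among the measured compounds shown here, in a functional assay on LOX IMVI cells (Homo sapiens) for cytotoxicity, read by sulforhodamine B assay, with a stated time of 48 h (on this read-out higher numbers stand for lower toxicity in this test and lower numbers for higher toxicity in this test), compound 1 gives 27500 nM, the higher of the two numbers measured so far. Compound 2 gives 6450 nM, and the gap between the two lies beyond the usual scatter, so compound 2 is the more toxic of the pair in this test. Compound 3 `ClCc1cccc(Cn2cnc3c(Cl)nc(Cl)nc32)c1` has not yet been measured. It differs from compound 1 by a single change: chloro in place of hydrogen on an aromatic carbon. For the measured compounds named here, no measured pair shows this change on its own, so there is no direct precedent. Compound 2 also carries two chlorines on its core and gives the lower number, which hints that a second chlorine may go with a lower concentration, although compound 2 differs from compound 3 elsewhere in its structure as well. The expected step is a 3.1-fold lower number from compound 1 to compound 3 (0.49 log units; beyond the scatter) in this assay. Compound 3 is therefore estimated at 9000 nM, with a range from 3500 nM to 25000 nM.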

Compound 3, concentration lethal to 50% of the cells: 6910 nM
The estimate for compound 3 lay 1.3-fold (0.11 log units) above the measured number; measured number inside the range.
By their numbers in this assay, from the lowest: compounds 2 and 3 (each within the scatter of the next); then compound 1.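

With chloro in place of hydrogen on an aromatic carbon between two ring nitrogen atoms, this assay gives a 4.0-fold lower number from compound 1 to compound 3 (0.60 log units; beyond the scatter), so this single added atom is enough to shift toxicity in this test. Until now, the only hint came from a compound that differed in more than one place, whereas this pair isolates the change at this one position. No evidence is available to explain why the number falls.

From the compounds shown here alone, whether this step is particular to chloro remains open, since an amine, a methoxy group or a methyl group at the same position could give a quite different number. It is also unclear whether the same step would appear in a compound whose chloromethyl group sits elsewhere.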